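The source may report more compounds than this note shows. Statements on the series, on what has been measured and on what is new or still open speak of the compounds shown alone.

Compound 1, `COCCn1nc(-c2cccnc2)c2ccccc2c1=O`, gives 9330 nM in a functional assay (trachea) with Cavia porcellus as the target; a higher number here means a weaker inhibitor, a lower number a stronger inhibitor.
Compound 2, `CCOC(=O)Cn1nc(-c2cccnc2)c2ccccc2c1=O`, gives 43700 nM in this assay.

Among the measured compounds shown here, compound 2 stands at the highest of these two numbers, with compound 1 as its nearest neighbour; the step of a 4.7-fold higher number from compound 1 to compound 2 (0.67 log units; beyond the scatter) is the only measured step in the set. Compound 3, `O=C(O)c1ccc(Cn2nc(-c3cccnc3)c3ccccc3c2=O)cc1`, differs from compound 2 by 4-carboxyphenyl in place of ethoxycarbonyl on a saturated chain carbon bound to an aromatic nitrogen. For the measured compounds named here, the step of a 4.7-fold higher number from compound 1 to compound 2 (0.67 log units; beyond the scatter) is the only one that bears on compound 3, and only loosely: it shows that swapping the group on this saturated chain carbon bound to an aromatic nitrogen moved the number by a modest amount, but no measured compound carries a 4-carboxyphenyl, so its direction cannot be read from the data. A modest step back towards the level of compound 1 is expected, with wide uncertainty. For compound 3 the estimated value in this assay is 20000 nM, expected to lie between 4000 nM and 100000 nM, which means an expected step of a 2.2-fold lower number from compound 2 to compound 3 (0.34 log units; beyond the scatter).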

Compound 3, half-maximal inhibitory concentration: 17000 nM
Compound 3: the middle estimate sits 1.2-fold (0.07 log units) above what was measured; the measured number falls inside the stated range.
By their numbers in this assay, from the lowest: compounds 1 and 3 (each within the scatter of the next); then compound 2.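

On a saturated chain carbon bound to an aromatic nitrogen, the position also tolerates a group with more heavy atoms and a six-membered aromatic ring: in this assay, 4-carboxyphenyl in place of ethoxycarbonyl gives a 2.6-fold lower number from compound 2 to compound 3 (0.41 log units; beyond the scatter) and so recovers much of what ethoxycarbonyl lost. Against methoxymethyl, the same group gives a 1.8-fold higher number from compound 1 to compound 3 (0.26 log units; within the scatter), so these two very different groups cannot be told apart here. Of the three groups, only ethoxycarbonyl stands apart from the other two. Nothing available explains these numbers.

On these data alone, it remains open whether the ring or its carboxylic acid accounts for the result, a question that a plain phenyl, or an amine in place of the acid, could help settle. As far as these compounds go, it is also open whether a longer chain at this position would bring a number clearly lower than those seen so far.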